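Compound 4: replacing carbamoylmethoxy on the shared core

The compounds below may be only part of what the source reports. "The series", "measured", "known", "first", "only" and "open" are said of these compounds alone.

Measured in an ADME assay on Huh-7 cells (Homo sapiens) for cytotoxicity, with a stated time of 72 h; a lower number here means that less compound is tolerated, a higher number that more compound is tolerated:
- Compound 1 `CCOc1cccc2c1S(=O)(=O)N=C2C1=C(O)[C@H](C(C)C)N(Cc2ccccc2)C1=O`: > 33000 nM
- Compound 2 `CC(C)(C)[C@H]1C(O)=C(C2=NS(=O)(=O)c3c(OCC(N)=O)cccc32)C(=O)N1Cc1ccc(F)c(Cl)c1`: > 33000 nM
- Compound 3 `CC(C)(C)CCN1C(=O)C(C2=NS(=O)(=O)c3c(OCC(N)=O)cccc32)=C(O)[C@@H]1C(C)(C)C`: > 33000 nM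

Each of these entries is a limit of the assay and not a number. Compound 3 stands at > 33000 nM, which is likewise only a limit. It has company there, for the measured set offers (the limit of > 33000 nM in this assay, at which 3 of the 3 values shown sit).

Compound 4 `CC(C)(C)CCN1C(=O)C(C2=NS(=O)(=O)c3c(CCS(C)(=O)=O)cccc32)=C(O)[C@@H]1C(C)(C)C` has not yet been measured. It differs from compound 3 in one place: 2-(methylsulfonyl)ethyl in place of carbamoylmethoxy on an aromatic carbon. Here 2-(methylsulfonyl)ethyl stands in place of carbamoylmethoxy on an aromatic carbon.

Among the compounds with values here, only one measured step can be consulted, a step that the two limits leave unreadable from compound 2 to compound 3. That step has no readable size, and it concerns neopentyl in place of 3-chloro-4-fluorophenyl, not the carbamoylmethoxy group. Within the data shown here, no measured step therefore gives a size for the present change. With nothing pointing either way, no change beyond the scatter is expected in this assay, and compound 4 is expected to sit at the same limit. The expected step is a number no higher from compound 3 to compound 4 (the limit leaves the size open). The estimate for compound 4 is 33000 nM. The expected range for compound 4 runs from 15000 nM to 33000 nM.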

Compound 4, half-maximal cytotoxic concentration: > 33000 nM
Compound 4 was reported as a limit (the forecaster's own chance of this, stated with the estimate: 80%); the middle value sits exactly at the limit.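

In this assay, no step can be read from compound 3 to compound 4, as both entries are limits of the assay and not numbers: the limit of > 33000 nM in this assay, at which 4 of the 4 values shown sit.

The compounds shown leave open whether 2-(methylsulfonyl)ethyl in place of carbamoylmethoxy changes anything in this assay, and where the half-maximal cytotoxic concentration of any of the four compounds actually lies.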